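Methyl for fluoro on the aryl ring of compound 3

The source may hold more compounds than are shown below. What is called first, only, known or untested is meant among the compounds shown, and "the series" means these compounds.

Compound 1 `Cc1nn(C)c2c1C(c1ccccc1Cl)=NCCN2CCCN(C)C` gives only a limit in a functional assay on the whole organism for positive allosteric modulation, with Rattus norvegicus as the target (on this read-out lower numbers stand for an effect already at smaller amounts and higher numbers for an effect only at larger amounts of compound), namely > 10 mg/kg. Compound 2 `Cc1nn(C)c2c1C(c1cccc(F)c1)=NCCN2CCCN(C)C` likewise gives only a limit, > 10 mg/kg. The step that the two limits leave unreadable from compound 1 to compound 2 cannot be read, since both values sit at the limit of > 10 mg/kg in this assay, at which 2 of the 2 values shown sit. Compound 3 `Cc1cccc(C2=NCCN(CCCN(C)C)c3c2c(C)nn3C)c1` differs from compound 2 by methyl in place of fluoro on an aromatic carbon. No readable measured step bears on this change, so compound 2 offers no placing of its own beyond its limit, and nothing in the series points either way. Compound 3 is therefore expected to sit near 15 mg/kg, with a range from 5 mg/kg to 40 mg/kg. The step that the limit leaves unreadable from compound 2 to compound 3 is an estimate only and is expected to stay within the scatter.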

Compound 3, minimum effective dose: > 10 mg/kg
Compound 3: no number, only a limit; the forecaster's own chance of this, stated with the estimate: 70%; the middle value lies beyond the limit too.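

Compound 3 joins compound 1 and compound 2 in giving only a limit, so no step among them can be read: the limit of > 10 mg/kg in this assay, at which 3 of the 3 values shown sit.

Going by these compounds, whether 2-chlorophenyl, 3-fluorophenyl and 3-methylphenyl differ at all in this assay remains open.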